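Pyridin-4-yl to 4-fluorophenyl on a carbonyl carbon

The compounds below may be only part of what the source reports. "The series", "measured", "known", "first", "only" and "open" are said of these compounds alone.

Going by the values given here, in an ADME assay on cells (Hepatocyte, Homo sapiens) for metabolic stability (on this read-out higher numbers stand for a longer-lived compound and lower numbers for a shorter-lived compound), compound 1 (`O=C(OC1CCC(CN2CCN(c3cc(=O)c4cc(C(F)(F)F)cc([N+](=O)[O-])c4s3)CC2)CC1)c1ccncc1`) gives 0.075 h as one of only two true numbers in this small set. The other comes from compound 3 (`O=C(OC1CCC(CN2CCN(c3cc(=O)c4cc(C(F)(F)F)cc([N+](=O)[O-])c4s3)CC2)CC1)c1ccc(C(F)(F)F)cc1`), which gives 0.117 h and carries 4-(trifluoromethyl)phenyl in place of pyridin-4-yl on a carbonyl carbon. Compound 2 (`CC(=O)OC1CCC(CN2CCN(c3cc(=O)c4cc(C(F)(F)F)cc([N+](=O)[O-])c4s3)CC2)CC1`), with methyl at that place, reports only a limit (< 0.15 h) and no number. Its steps to the other two therefore have no readable size.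

Compound 4 (`O=C(OC1CCC(CN2CCN(c3cc(=O)c4cc(C(F)(F)F)cc([N+](=O)[O-])c4s3)CC2)CC1)c1ccc(F)cc1`) has not been measured, and its difference from compound 1 is this (4-fluorophenyl in place of pyridin-4-yl on a carbonyl carbon): 4-fluorophenyl in place of pyridin-4-yl on a carbonyl carbon. Among the compounds with values here, that swap resembles the only readable step, a 1.6-fold higher number from compound 1 to compound 3 (0.19 log units; within the scatter) and so no step beyond the scatter is expected in this assay here. The estimated step is a 1.3-fold higher number from compound 1 to compound 4 (0.12 log units; within the scatter) and it should stay small. The estimate for compound 4 is 0.1 h as a middle value, expected to fall from 0.05 h to 0.2 h on repeat measurement.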

Compound 4, half-life: 0.0983 h
Compound 4: the middle estimate sits 1.0-fold (0.01 log units) above what was measured, and the stated range covers the measured number.
By their numbers in this assay, from the lowest: compounds 1, 4 and 3 (each within the scatter of the next).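

In this assay, 4-fluorophenyl in place of pyridin-4-yl on a carbonyl carbon gives a 1.3-fold higher number from compound 1 to compound 4 (0.12 log units; within the scatter), while fluoro in place of trifluoromethyl on an aromatic carbon gives a 1.2-fold lower number from compound 3 to compound 4 (0.08 log units; within the scatter). Neither a carbon-only aromatic ring in place of pyridin-4-yl nor the choice between these two ring substituents therefore shifts the number beyond the scatter in these compounds. Compound 2 reports only a limit, so its step to compound 4 cannot be read, like its other steps: the limit of < 0.15 h in this assay, at which 1 of the 4 values shown sits.

Still open, from the compounds shown here alone, is whether a group of another kind on this carbonyl carbon, such as a cyclopropyl ring or a longer chain, would give a step beyond the scatter. So is whether an amide, with nitrogen in place of the oxygen next to a carbonyl group, would do so.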